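A methyl added to the ketone aryl of compound 2

The compounds below may be only part of what the source reports. "The series", "measured", "known", "first", "only" and "open" are said of these compounds alone.

Compound 2 `COc1ccc(-c2nnc(CCC(=O)c3ccc(C)cc3)o2)cc1OC` was tested in a functional assay on the whole organism (strain Wistar) for inhibition, with Rattus norvegicus as the target, with stated times of 30 min and 3 h, at a dose of 20 mg/kg by the oral route (on this read-out higher numbers stand for more inhibition at the one dose given (going by the name of the read-out) and lower numbers for less inhibition), and gave 72.6%, which places it second highest of the three measured numbers. Compound 1 `COc1ccc(-c2nnc(CCC(=O)c3ccc(C)cc3)o2)cc1` gives 89.5% in this assay, and compound 3 `Cc1ccc(C(=O)CCc2nnc(-c3ccccc3)o2)c(C)c1` gives 58%. For the measured compounds named here, the only single-point step among the measured compounds is a number 16.9 percentage points lower from compound 1 to compound 2 (beyond the scatter), a change of a methoxy group that does not resemble the change now considered. Compound 4 `COc1ccc(-c2nnc(CCC(=O)c3ccc(C)cc3C)o2)cc1OC` differs from compound 2 by methyl in place of hydrogen on an aromatic carbon; read one bond further out, 4-methylphenyl becomes 2,4-dimethylphenyl. Going by the values given here, no measured step isolates this change: compound 3 carries the same 2,4-dimethylphenyl group but also lacks both methoxy groups, so its value can only be noted, not used as a step. Among the compounds with values here, with no direct precedent, the expected step for compound 4 is a number 7.6 percentage points lower from compound 2 to compound 4 (within the scatter), a small lowering that may well lie within the scatter. Compound 4 is therefore estimated to give 65% in this assay, within a range of 48% to 82%.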

Compound 4, a percentage reported as inhibition, in the whole organism at one dose (the size of the read-out at that dose, not a potency): 75.3%
For compound 4 the middle estimate is 10.3 percentage points below the measured one, and the stated range covers the measured number.
By their numbers in this assay, from the lowest: compound 3; then compounds 2 and 4 (each within the scatter of the next); then compound 1.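

In this assay the step is a number 2.7 percentage points higher from compound 2 to compound 4 (within the scatter), so with both methoxy groups in place, the 4-methylphenyl and 2,4-dimethylphenyl forms cannot be told apart on this read-out. For the compounds shown here, this is the first single-place reading at this aromatic carbon, ortho to a large group and meta to a methyl group, and it shows that adding a methyl there brings no change beyond the scatter at the one dose given. No measured evidence bears on the reason for this result.

Going by these compounds alone, whether the same methyl would read the same way alongside the single methoxy group of compound 1 remains open. Also open, from the compounds shown here alone, is how a different group at this carbon, such as an ethyl, a chlorine atom or an amine, would read.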